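A few compounds are considered here, and "the series" means these few. Any claim that something is new, unique, unknown or untested is made for them only; others in the source may bear on it.

Measured compounds in an ADME assay on HEp-2 cells (Homo sapiens) for cytotoxicity, read by CCK-8 assay, with a stated time of 5 days; a higher number here means that more compound is tolerated, a lower number that less compound is tolerated:
compound 1 `Cc1ccc2nc(N3CCCc4ccc(F)cc4C3)cc(NCCN)c2c1`: > 3200 nM, a limit of the assay
compound 2 `Cc1ccc2nc(N3CCCc4ccc(F)cc4C3)cc(NCCN(C)C)c2c1`: 89000 nM

Going by the values given here, compound 2 carries the only number of the pair in this assay. The reading for compound 1 is a limit, namely (the limit of > 3200 nM in this assay, at which 1 of the 2 values shown sits). The change from compound 1 to compound 2, dimethylamino in place of amino on a saturated chain carbon, two bonds along the chain from a nitrogen on an aromatic ring, gives a step that the limit leaves unreadable from compound 1 to compound 2.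

Compound 3 `Cc1ccc2nc(N3CCCc4ccc(F)cc4C3)cc(NC(C)CN)c2c1` differs from compound 2 by 1-(aminomethyl)ethyl in place of 2-(dimethylamino)ethyl on a nitrogen on an aromatic ring. It returns to a primary amine, as in compound 1, but on a shorter, branched chain. Among the compounds with values here, the one measured step does not bear on it readably, since the limit on compound 1 hides its size; no measured step covers the branching. The expectation for compound 3 is therefore broad, a step of a 3.0-fold lower number from compound 2 to compound 3 (0.47 log units; beyond the scatter) being expected, in the direction of less compound tolerated, with the outcome for compound 3 estimated at 30000 nM, between 5000 nM and 100000 nM.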

Compound 3, half-maximal cytotoxic concentration: 25000 nM
For compound 3 the middle estimate is 1.2-fold (0.08 log units) above the measured one; the range from low to high includes it.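

In this assay, 1-(aminomethyl)ethyl in place of 2-(dimethylamino)ethyl on a nitrogen on an aromatic ring gives a 3.6-fold lower number from compound 2 to compound 3 (0.55 log units; beyond the scatter). Going by these compounds alone, this is the first readable step, and it shows that changing this side chain alone, with the shared core unchanged, can move the tolerated concentration in this assay beyond the scatter. Both steps that start at compound 1 cannot be read, because the reading of compound 1 in this assay is a limit: the limit of > 3200 nM in this assay, at which 1 of the 3 values shown sits.

The step from compound 2 to compound 3 changes the end of the chain and its branching together, and the limit on compound 1 leaves the share of each open. As far as these compounds go, how this assay would respond to a longer chain ending in dimethylamino, or to a hydroxyl or a carboxylic acid in place of the terminal amine, also remains open, so the direction seen here cannot yet be called a trend for this position.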